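The source may hold more compounds than are shown below. What is called first, only, known or untested is meant among the compounds shown, and "the series" means these compounds.

Compound 2, `CC[C@H](C)[C@H](NC(=O)CN(c1ncnc2c1ncn2C1CCCCO1)C1CC1)C(=O)OCc1ccccc1`, is the weakest point of the three measured compounds: in a functional assay on the whole organism (Tail, strain ICR) with Mus musculus as the target, in the tail flick test, with a stated time of 60 min, at a dose of 25 umol/kg by the oral route (on this read-out higher numbers stand for a stronger effect at the one dose given and lower numbers for a weaker effect), compound 2 gives 27.4%, whereas compound 1, `NCCCC[C@H](NC(=O)CN(c1nc(Cl)nc2[nH]cnc12)C1CC1)C(=O)OCc1ccccc1`, gives 41.2% and compound 3, `O=C(CN(c1nc(Cl)nc2[nH]cnc12)C1CC1)N[C@@H](CCC(=O)OCc1ccccc1)C(=O)OCc1ccccc1`, gives 53.7%, both steps to compound 2 lying beyond the scatter. Among the compounds with values here, the only single-point step measured so far is a number 12.5 percentage points higher from compound 1 to compound 3 (beyond the scatter), which shows that a change on the side chain can shift the read-out by a modest amount. Compound 4, `CC(C)(C)OC(=O)NCCCC[C@H](NC(=O)CN(c1ncnc2c1ncn2C1CCCCO1)C1CC1)C(=O)OCc1ccccc1`, keeps the core of compound 2 and differs by 4-((tert-butoxycarbonyl)amino)butyl in place of sec-butyl on a saturated chain carbon bound to an amide-type nitrogen and a carbonyl carbon. Within the data shown here, no measured step covers this exchange directly; compound 1 carries a related side chain on the other core and stands above compound 2, which is the only pointer to direction. On that basis compound 4 is expected to sit above compound 2 by a modest margin, with the expected step of a number 9.6 percentage points higher from compound 2 to compound 4 (within the scatter). The estimate for compound 4 in this assay is 37%, in the range 23% to 52%.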

Compound 4, a percentage reported as activity, at one dose (the size of the read-out at that dose, not a potency): 32.7%
Beside the measured number, compound 4's estimate is 4.3 percentage points above it; low and high end bracket the measured number.
By their numbers in this assay, from the lowest: compounds 2, 4 and 1 (each within the scatter of the next, the first and the last beyond it); then compound 3.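

Within the data shown here, on the core of compound 2, in this assay, the exchange gives a number 5.3 percentage points higher from compound 2 to compound 4 (within the scatter), the first reading at this position on a saturated chain carbon bound to an amide-type nitrogen and a carbonyl carbon. Replacing sec-butyl with the much larger 4-((tert-butoxycarbonyl)amino)butyl, which brings 1 hydrogen-bond donor and 2 hydrogen-bond acceptors, therefore leaves the read-out within the scatter. No supporting measurement is available to explain this outcome.

Still open, going by these compounds, is what a free primary amine or a carboxylic acid at the end of the butyl chain would give on the core of compound 2. Compound 1 and compound 4 differ in more than one place, and the part played by the core remains unresolved.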